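Benzyl halogen position in a triazole-linked chromone series

The compounds below may be only part of what the source reports. "The series", "measured", "known", "first", "only" and "open" are said of these compounds alone.

Among the compounds with values here, the series so far holds two measured compounds that share one core and differ only in the benzyl group on a saturated chain carbon bound to an aromatic nitrogen. Compound 1 `O=c1ccoc2cc(OCc3cn(Cc4ccc(F)cc4)nn3)ccc12` carries a 4-fluorophenyl there and in a functional assay on QGY7701 cells (Homo sapiens) for cytotoxicity, read by MTT assay, with a stated time of 48 h (a higher number here means a weaker inhibitor, a lower number a stronger inhibitor), compound 1 gives 14400 nM. Compound 2 `O=c1ccoc2cc(OCc3cn(Cc4cccc(Cl)c4)nn3)ccc12` carries a 3-chlorophenyl, and in this assay compound 2 gives 28400 nM. Within the data shown here, of the two numbers so far, compound 2 stands apart from compound 1 only by a 2.0-fold higher number from compound 1 to compound 2 (0.29 log units; within the scatter), so the two compounds are not distinguished by this pair of measurements.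

Compound 3 `O=c1ccoc2cc(OCc3cn(Cc4ccccc4F)nn3)ccc12` is the next point in the same position: 2-fluorophenyl in place of 3-chlorophenyl on a saturated chain carbon bound to an aromatic nitrogen. Among the measured compounds shown here, the only step that bears on it, a 2.0-fold higher number from compound 1 to compound 2 (0.29 log units; within the scatter), moved a halogen about the same ring and stayed within the scatter. For the measured compounds named here, nothing measured here speaks for a change of size beyond that, so the expected step is a 1.4-fold lower number from compound 2 to compound 3 (0.15 log units; within the scatter), set between the two numbers known. On that basis compound 3 is estimated at 20000 nM in this assay, with a range from 7000 nM to 60000 nM.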

Compound 3, half-maximal inhibitory concentration: 36900 nM
Compound 3: the middle estimate sits 1.8-fold (0.27 log units) below what was measured; the range from low to high includes it.
By their numbers in this assay, from the lowest: compounds 1, 2 and 3 (each within the scatter of the next, the first and the last beyond it).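

Among the fluorophenyl compounds, the place of the fluorine now has a readable effect on the number: a 2.6-fold higher number from compound 1 to compound 3 (0.41 log units; beyond the scatter), the first step at this position that clears the scatter, though it remains modest. The change from 3-chlorophenyl to 2-fluorophenyl does not separate its two compounds: a 1.3-fold higher number from compound 2 to compound 3 (0.11 log units; within the scatter), so compound 2 cannot be told apart from compound 3 in this assay, just as it could not be told apart from compound 1, and only the two ends of the series are distinguished. No supporting measurement accounts for the difference between the 4-fluorophenyl and 2-fluorophenyl compounds.

Compound 2 differs from the other two in both the halogen and its place on the ring, so a 3-fluorophenyl or 4-chlorophenyl group would be needed to read those two changes apart. From the compounds shown here alone, whether a halogen is needed at all remains open, as does how an unsubstituted phenyl, a methoxyphenyl, an aminophenyl or a longer chain in place of the benzyl group would read in this assay.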